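The source may hold more compounds than are shown below. What is called first, only, known or untested is meant among the compounds shown, and "the series" means these compounds.

Measured so far in a functional assay on HEK293 cells for agonist activity at D(4) dopamine receptor (Homo sapiens), read by FLIPR; on this read-out higher numbers stand for larger maximal responses and lower numbers for smaller maximal responses:
compound 1, `N#Cc1cccc(C(=O)NCN2CCC(c3cccc[n+]3[O-])CC2)c1`: 69%
compound 2, `CCOc1cccc(C(=O)NCN2CCC(c3cccc[n+]3[O-])CC2)c1`: 54%
compound 3, `O=C(CN1CCC(c2cccc[n+]2[O-])CC1)Nc1ccccc1F`: 63%

Compound 1 gives the largest of the three numbers in this assay, but compound 3 sits within the scatter of it, so no order between those two can be read. The only clear gap is to compound 2: a number 15 percentage points lower from compound 1 to compound 2 (beyond the scatter), a modest drop that follows ethoxy in place of cyano on an aromatic carbon.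

Compound 4, `O=C(NCN1CCC(c2cccc[n+]2[O-])CC1)c1ccc(F)c(Cl)c1`, has not yet been run in this assay. It differs from compound 1 as follows: 3-chloro-4-fluorophenyl in place of 3-cyanophenyl on a carbonyl carbon.

Going by the values given here, the one measured step that bears on this change is the one from compound 1 to compound 2, where the same 3-cyanophenyl group was replaced on its aromatic carbon and the response fell by a modest amount. Here the replacing group is 3-chloro-4-fluorophenyl, a different substitution pattern, so that step is only a loose guide. Compound 3, with its fluorine-bearing aryl group on the shared core, stays within the scatter of compound 1, which argues against a large loss. The expectation is therefore a small step down or none beyond the scatter: a number 9 percentage points lower from compound 1 to compound 4 (within the scatter).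

The estimate for compound 4 in this assay is 60%, with a range from 45% to 78%.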

Compound 4, largest response reached (reported as efficacy), in percent of the reference or control that the assay uses: 67%
For compound 4 the middle estimate is 7 percentage points below the measured one; the measured number falls inside the stated range.
By their numbers in this assay, from the lowest: compounds 2, 3, 4 and 1 (each within the scatter of the next, the first and the last beyond it).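

In this assay, 3-chloro-4-fluorophenyl takes the place of 3-cyanophenyl on the carbonyl carbon with a number 2 percentage points lower from compound 1 to compound 4 (within the scatter), so among these compounds the nitrile, with its triple bond and its hydrogen-bond acceptor, is not needed to keep the response at this place. The earlier step, a number 15 percentage points lower from compound 1 to compound 2 (beyond the scatter), therefore cannot be read as a penalty for losing the nitrile as such, since it appears with ethoxy and not with the two halogens. No supporting data accompany these numbers, so the difference between the two replacements stays unexplained.

Open, on these data alone, is whether a phenyl group with chlorine alone or fluorine alone would match 3-chloro-4-fluorophenyl, and how a carboxylic acid or a dimethylamino group would fare on the same aromatic ring. Compound 3 differs from compound 1 in more than one place, so the compounds shown do not tell whether the same replacements would hold with the amide arrangement of compound 3.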